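The source may hold more compounds than are shown below. What is called first, only, known or untested is meant among the compounds shown, and "the series" means these compounds.

Compound 1 `COc1ccc(OC)c(C2OC(c3cc(OC)c(OC)c(OC)c3)=NN2C(C)=O)c1` and compound 2 `COc1cc(C2=NN(C(C)=O)C(c3ccc(Cl)c(Cl)c3)O2)cc(OC)c1OC` share one core and differ only in the group on the saturated ring carbon. In a functional assay on BGC-823 cells (Homo sapiens) for antiproliferative activity, read by MTT assay, tested at 1 uM (a lower number here means a weaker effect, a higher number a stronger effect of the compound at the concentration tested), compound 1 gives 0.4% and compound 2 gives -0.8%, so compound 2 holds the bottom of the two numbers shown, though the step of a number 1.2 percentage points lower from compound 1 to compound 2 (within the scatter) keeps both within the scatter of each other. Compound 3 `COc1cc(C2=NN(C(C)=O)C(c3ccc(C(F)(F)F)cc3)O2)cc(OC)c1OC` changes the same place again: 4-(trifluoromethyl)phenyl in place of 3,4-dichlorophenyl on a saturated ring carbon. Going by the values given here, the only step bearing on this site, a number 1.2 percentage points lower from compound 1 to compound 2 (within the scatter), stayed within the scatter, so no step beyond the scatter is expected in this assay. Compound 3 is therefore estimated at 1%, range -8% to 10%. The expected step of a number 1.8 percentage points higher from compound 2 to compound 3 (within the scatter) lies within the scatter.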

Compound 3, a percentage reported as inhibition, at one concentration (the size of the read-out at that concentration, not a potency): 4.2%
For compound 3 the middle estimate is 3.2 percentage points below the measured one, and the stated range covers the measured number.
By their numbers in this assay, from the lowest: compounds 2, 1 and 3 (each within the scatter of the next).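

In this assay, a third substituted phenyl group on the saturated ring carbon, 4-(trifluoromethyl)phenyl, gives a step of a number 5 percentage points higher from compound 2 to compound 3 (within the scatter) and a step of a number 3.8 percentage points higher from compound 1 to compound 3 (within the scatter). Neither step separates the new group from the earlier two, so the three substituted phenyl groups on this carbon remain indistinguishable at the concentration tested. No evidence on hand bears on this result. On these data alone, whether a phenyl ring carrying an amine or a carboxylic acid, or a cyclohexyl group, at this carbon would move the read-out beyond the scatter stays open. As far as these compounds go, the effect of replacing the acetyl group also stays open.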